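Moving the amino group around the phenyl ring of compound 2

The source may hold more compounds than are shown below. What is called first, only, known or untested is meant among the compounds shown, and "the series" means these compounds.

Measured compounds:
compound 1 `Cc1cc(C(=O)Nc2cccc(NC(=O)COc3ccc4c(=O)ccoc4c3)c2)ccc1C(F)(F)F` gives 460 nM
compound 2 `Nc1ccc(C(=O)Nc2cccc(NC(=O)COc3ccc4c(=O)ccoc4c3)c2)cc1` gives 802 nM

Both numbers come from an assay on isolated protein for inhibition of Rho-associated protein kinase 1 (Homo sapiens), read by scintillation counting, radiometric assay and 33P incorporation, with a stated time of 40 min, in the presence of a further agent that is not named here; on this read-out higher numbers stand for weaker inhibition and lower numbers for stronger inhibition. Compound 2 sits at one end of the two numbers, but the step of a 1.7-fold higher number from compound 1 to compound 2 (0.24 log units; within the scatter) is within the scatter, so the two compounds cannot be told apart on this read-out. That step exchanged one aromatic group for another on the carbonyl carbon, and the measurement barely moved.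

Compound 3 `Nc1cccc(C(=O)Nc2cccc(NC(=O)COc3ccc4c(=O)ccoc4c3)c2)c1` has not been measured. It differs from compound 2 only in how the same atoms are joined: 3-aminophenyl in place of 4-aminophenyl on a carbonyl carbon. Within the data shown here, no measured step moves the amino group around its ring, so nothing in the data speaks directly to this change. Among the measured compounds shown here, the only related step, from compound 1 to compound 2, stayed within the scatter. In this assay compound 3 is therefore expected near compound 2, with the estimated step of a 1.1-fold higher number from compound 2 to compound 3 (0.03 log units; within the scatter) carrying wide uncertainty. The estimate for compound 3 is 850 nM, within the range 250 nM to 3000 nM.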

Compound 3, half-maximal inhibitory concentration: 670 nM
The estimate for compound 3 lay 1.3-fold (0.10 log units) above the measured number; measured number inside the range.
By their numbers in this assay, from the lowest: compounds 1, 3 and 2 (each within the scatter of the next).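

In this assay, the change to 3-aminophenyl in place of 4-aminophenyl on the carbonyl carbon gives a 1.2-fold lower number from compound 2 to compound 3 (0.08 log units; within the scatter) and so cannot be told apart from no change at all. This is the first direct look at where the amino group sits on this ring, and the two placements shown read alike. The step of a 1.5-fold higher number from compound 1 to compound 3 (0.16 log units; within the scatter) is also within the scatter, so compound 3, like compound 2, cannot be separated from compound 1, and no measurement is at hand to account for these results. The compounds shown leave open whether aminomethyl or a carboxylic acid in place of the amino group would give a number clearly apart from these three. They also leave open how a plain phenyl group, with no amino group, would read.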